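The source may hold more compounds than are shown below. What is called first, only, known or untested is meant among the compounds shown, and "the series" means these compounds.

Going by the values given here, compound 1, with the structure `S=C(Nc1ccccc1)N1N=C(c2ccccc2)CC1c1ccc2c(c1)OCCO2`, is the only compound of the pair that gives an actual number: in a functional assay on WM 266-4 cells (Homo sapiens) for antiproliferative activity, read by MTT assay, with a stated time of 48 h (a lower number here means a stronger inhibitor of growth, a higher number a weaker inhibitor of growth), compound 1 gives 3180 nM. Compound 2, the structure `S=C(Nc1ccccc1)N1N=C(c2ccccc2Br)CC1c1ccc2c(c1)OCCO2`, gives in this assay only a limit, > 200000 nM, which is the limit of > 200000 nM in this assay, at which 1 of the 2 values shown sits. Among the compounds with values here, the one step measured here, an at least 62-fold higher number from compound 1 to compound 2 (1.79 log units; beyond the scatter), is the only guide available, and it concerns a different group at a different ring position.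

Compound 3 has the structure `S=C(Nc1ccccc1)N1N=C(c2ccc(OCc3ccccc3)cc2)CC1c1ccc2c(c1)OCCO2`, and its change from compound 1 is benzyloxy in place of hydrogen on an aromatic carbon. Within the data shown here, no measured step matches that change; the bromo step shows only that a substituent on this ring can weaken growth inhibition sharply. Compound 3 is therefore expected to land weaker than compound 1, with a step of a 1.9-fold higher number from compound 1 to compound 3 (0.28 log units; within the scatter) carrying wide uncertainty. Compound 3 is estimated at 6000 nM, within a range from 800 nM to 60000 nM.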

Compound 3, concentration for 50% growth inhibition: 420 nM
Compound 3: middle estimate off by 14-fold (1.15 log units), on the high side, outside the stated range (below it).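

In this assay, benzyloxy in place of hydrogen on an aromatic carbon, para to a large group, gives a 7.6-fold lower number from compound 1 to compound 3 (0.88 log units; beyond the scatter). This shows that a substituent on this ring need not weaken growth inhibition: the bromo step of compound 2 had pointed only towards a loss, while compound 3 moves the number the other way. Nothing shown gives a cause for this gain.

The compounds shown leave open whether methoxy, a hydroxyl group or an amine at the same place would give a similar step, or whether the gain needs the whole benzyloxy group. Going by these compounds, how far compound 2 lies from the others also stays open, for its value is only a limit: the limit of > 200000 nM in this assay, at which 1 of the 3 values shown sits.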